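The source may hold more compounds than are shown below. What is called first, only, known or untested is meant among the compounds shown, and "the series" means these compounds.

Of the compounds shown here, three with a shared core have been measured in an ADME assay on microsomes from liver (Mus musculus, strain CD1) for metabolic stability, read by HPLC, using NADPH, with a stated time of 30 min, tested at 0.5 uM; on this read-out lower numbers stand for slow clearance and higher numbers for fast clearance. Compound 2 `CC(=O)Nc1cnc2[nH]c(=O)n([C@H]3CC[C@H](C(C)C)CC3)c(=O)c2c1` gives 1.4 mL.min-1.g-1, level with compound 1 `CC(=O)Nc1cnc2[nH]c(=O)n([C@H]3CC[C@H](C(C)(C)C)CC3)c(=O)c2c1`, which gives 1.4 mL.min-1.g-1, and together they hold the lowest of the three numbers. Compound 3 `CC(=O)Nc1cnc2[nH]c(=O)n([C@H]3CC[C@@H](C(C)C)CC3)c(=O)c2c1` stands apart at 10 mL.min-1.g-1. The data show a 7.1-fold higher number from compound 2 to compound 3 (0.85 log units; beyond the scatter), a gap that goes with the fact that compounds 2 and 3 differ only in the configuration as drawn.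

The next compound to be measured is compound 4 `CC[C@H]1CC[C@H](n2c(=O)[nH]c3ncc(NC(C)=O)cc3c2=O)CC1`. The change is hydrogen in place of methyl on a saturated chain carbon bound to a saturated chain carbon and a saturated ring carbon: isopropyl becomes ethyl, with hydrogen in place of methyl on a saturated chain carbon bound to a saturated chain carbon and a saturated ring carbon. The large configuration step offers little guidance here, as this change touches only that methyl. The closest evidence is a similar swap of methyl for hydrogen on the chain, which turned tert-butyl into isopropyl and gave no change at the digits printed from compound 1 to compound 2 (within the scatter). That is a single precedent, so the forecast is cautious, but on the strength of it no step beyond the usual scatter is expected in this assay, in either direction. The expected outcome is a 1.1-fold higher number from compound 2 to compound 4 (0.03 log units; within the scatter). Compound 4 is estimated at 1.5 mL.min-1.g-1, with an expected range from 0.7 mL.min-1.g-1 to 3.5 mL.min-1.g-1.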

Compound 4, intrinsic clearance in microsomes: 0.5 mL.min-1.g-1
Beside the measured number, compound 4's estimate is 3.0-fold (0.48 log units) above it, outside the stated range (below it).
By their numbers in this assay, from the lowest: compound 4; then compounds 1 and 2 (each within the scatter of the next); then compound 3.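

In this assay, the same swap of hydrogen for methyl on the chain does not behave alike at each chain length: starting from tert-butyl it gives no change at the digits printed from compound 1 to compound 2 (within the scatter), while starting from isopropyl it gives a 2.8-fold lower number from compound 2 to compound 4 (0.45 log units; beyond the scatter). Taken as a single change, ethyl in place of tert-butyl gives a 2.8-fold lower number from compound 1 to compound 4 (0.45 log units; beyond the scatter), so among the three compounds drawn in this configuration, the one carrying ethyl, the shortest chain shown, has the lowest clearance number, while the tert-butyl and isopropyl compounds do not separate. Nothing in the information at hand explains why clearance falls only at this last shortening of the chain.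

The compounds shown leave open whether a lone methyl on this saturated ring carbon would continue the fall, and whether a longer chain, an amine or a carboxylic acid there would break with it. They also leave open whether an ethyl compound drawn in the configuration of compound 3 would stand as far above compound 4 as compound 3 stands above compound 2.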